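From 2-chlorophenyl to 4-chlorophenyl: compound 3 and compound 4

The compounds below may be only part of what the source reports. "The series", "measured", "known", "first", "only" and "open" are said of these compounds alone.

Among the measured compounds shown here, compound 3 `CCCCc1nc(Cl)c(C2NC(=O)NC(C)=C2C(=O)Nc2ccccc2Cl)[nH]1` gives 7.6 ug/mL in an ADME assay on Vero cells (Chlorocebus sabaeus) for cytotoxicity, read by MTT assay, with a stated time of 72 h (a lower number here means a stronger inhibitor, a higher number a weaker inhibitor), the only actual number among its close relatives. Compound 2 `CCCCc1nc(Cl)c(C2NC(=O)NC(C)=C2C(=O)Nc2ccccc2F)[nH]1` gives > 10 ug/mL, which is a limit of the assay and not a number. For compound 1 `CCCCc1nc(Cl)c(C2NC(=O)NC(C)=C2C(=O)Nc2cccc(OC)c2)[nH]1` the entry reads "not determined" (no result reported). The next analogue, compound 4 `CCCCc1nc(Cl)c(C2NC(=O)NC(C)=C2C(=O)Nc2ccc(Cl)cc2)[nH]1`, keeps the shared core and differs from compound 3 in one place: 4-chlorophenyl in place of 2-chlorophenyl on an amide-type nitrogen. For the measured compounds named here, only one measured step bears on this, and only loosely, for it swaps one halogen for another and leaves the place of the halogen unchanged: an at least 1.3-fold lower number from compound 2 to compound 3 (0.11 log units; that floor lies within the scatter). Going by the values given here, no measured step shows what the change from 2-chlorophenyl to 4-chlorophenyl does in this assay. No step beyond the scatter is therefore expected, in either direction, and the estimated change is a 1.1-fold higher number from compound 3 to compound 4 (0.05 log units; within the scatter). For compound 4 the estimated value is 8.5 ug/mL, with an expected range of 4 ug/mL to 16 ug/mL.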

Compound 4, half-maximal inhibitory concentration: 9.4 ug/mL
Beside the measured number, compound 4's estimate is 1.1-fold (0.04 log units) below it, within the range that was stated.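

Among the compounds shown here, replacing 2-chlorophenyl with 4-chlorophenyl on an amide-type nitrogen gives the first pair of actual numbers in this set, and in this assay the change produces a 1.2-fold higher number from compound 3 to compound 4 (0.09 log units; within the scatter). Compound 3 and compound 4 therefore cannot be told apart in this assay, so moving the chlorine between these two named groups has no readable effect here. Compound 2 gives > 10 ug/mL, a limit of the assay and not a number, so an at least 1.0-fold lower number from compound 2 to compound 4 (0.02 log units; that floor lies within the scatter) is only a floor and shows no separation: the limit of > 10 ug/mL in this assay, at which 1 of the 4 values shown sits.

The compounds shown leave open whether a group of another kind on that phenyl ring, such as an amine or a carboxylic acid, would move the value beyond the scatter. They also leave open what a longer chain in place of the phenyl ring on that nitrogen would do.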